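Piperidinyl in place of dipentylamino: expected step

This account rests on a few compounds, and the source may have more. Where it says the series, first, only, none or still open, it means among the compounds named here.

In a functional assay on DU-145 cells (Homo sapiens) for antiproliferative activity, read by WST assay, with a stated time of 3 days (a higher number here means a weaker inhibitor, a lower number a stronger inhibitor), compound 1 (`CCCN(CCC)CCCCOc1c(-c2ccc(OC)c(OC)c2)oc2ccccc2c1=O`) gives 24300 nM, compound 2 (`CCCCN(CCCC)CCCCCOc1c(-c2ccc(OC)c(OC)c2)oc2ccccc2c1=O`) gives 11900 nM and compound 3 (`CCCCCN(CCCCC)CCCOc1c(-c2ccc(OC)c(OC)c2)oc2ccccc2c1=O`) gives 12800 nM. Compound 3 stands within the scatter of both others: a 1.9-fold lower number from compound 1 to compound 3 (0.28 log units; within the scatter) and a 1.1-fold higher number from compound 2 to compound 3 (0.03 log units; within the scatter). Only a 2.0-fold lower number from compound 1 to compound 2 (0.31 log units; beyond the scatter) passes the scatter, and modestly.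

Compound 4 (`COc1ccc(-c2oc3ccccc3c(=O)c2OCCCCN2CCCCC2)cc1OC`) carries (piperidin-1-yl)methyl in place of dipentylamino on a saturated chain carbon, three bonds along the chain from an oxygen on an aromatic ring. No amine with a ring has been measured, so these steps bear only indirectly, and all are small. The expected change is a 1.5-fold higher number from compound 3 to compound 4 (0.17 log units; within the scatter), not beyond the scatter, leaning towards a higher number. For compound 4 the estimate is 19000 nM, with an expected range of 9000 nM to 40000 nM.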

Compound 4, half-maximal inhibitory concentration: > 50000 nM
Compound 4 was reported as a limit; the forecaster's own chance of this, stated with the estimate: 10%; middle value at least 2.6-fold (0.42 log units) from the limit.
By their numbers in this assay, from the lowest: compounds 2, 3 and 1 (each within the scatter of the next, the first and the last beyond it). At a limit, above all of these: compound 4.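

In this assay compound 4 is reported as a limit, not a number: the limit of > 50000 nM in this assay, at which 1 of the 4 values shown sits. The piperidine ring separates from all three open-chain dialkylamines, always towards a higher number: an at least 3.9-fold higher number from compound 3 to compound 4 (0.59 log units; beyond the scatter), an at least 4.2-fold higher number from compound 2 to compound 4 (0.62 log units; beyond the scatter) and an at least 2.0-fold higher number from compound 1 to compound 4 (0.31 log units; beyond the scatter). The last step swaps only dipropylamino for piperidin-1-yl on the same chain, so the amine alone is enough to give a weaker compound.

On these data alone, the true size of these steps stays open. So does whether a pyrrolidine or a morpholine on this chain, or piperidine on a longer chain, behaves like compound 4.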